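Swapping a Pentyl Chain for a Butylphenyl Ring

The compounds below may be only part of what the source reports. "The series", "measured", "known", "first", "only" and "open" are said of these compounds alone.

Of the compounds shown here, two of a shared core have been measured in a functional assay on HeLa cells (Homo sapiens) for antiproliferative activity, read by MTT assay, with a stated time of 3 days; a higher number here means a weaker inhibitor, a lower number a stronger inhibitor. Compound 1 `CCCCCCC#Cc1cn(C/C=C/CN2C(=O)c3ccccc3C2=O)c(=O)[nH]c1=O` gives 34000 nM. Compound 2 `CCCCCC#Cc1cn(C/C=C/CN2C(=O)c3ccccc3C2=O)c(=O)[nH]c1=O` gives 91000 nM, the higher of the two numbers, so it is the weaker inhibitor of the pair, with compound 1 as its nearest neighbour. Within the data shown here, the only measured step is a 2.7-fold higher number from compound 1 to compound 2 (0.43 log units; beyond the scatter), a modest change for shortening the chain. Compound 3 `CCCCc1ccc(C#Cc2cn(C/C=C/CN3C(=O)c4ccccc4C3=O)c(=O)[nH]c2=O)cc1` differs from compound 2 by 4-butylphenyl in place of pentyl on a triple-bonded carbon. Among the measured compounds shown here, no measured step turns a chain into a ring, so that single step is all that bears on it, and it shows this region of the molecule matters modestly. A change as large as this one is expected to move the number beyond the scatter, and a move back toward or past the number of compound 1 seems somewhat more likely than a further rise. Compound 3 is therefore estimated at 30000 nM, with a range from 7000 nM to 130000 nM, an expected step of a 3.0-fold lower number from compound 2 to compound 3 (0.48 log units; beyond the scatter).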

Compound 3, half-maximal inhibitory concentration: 94000 nM
Compound 3: the middle estimate sits 3.1-fold (0.50 log units) below what was measured; the measured number falls inside the stated range.
By their numbers in this assay, from the lowest: compound 1; then compounds 2 and 3 (each within the scatter of the next).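

Swapping pentyl for 4-butylphenyl on the triple-bonded carbon adds a six-membered aromatic ring of carbon only and takes the group from 5 to 10 heavy atoms, yet this assay shows a 1.0-fold higher number from compound 2 to compound 3 (0.01 log units; within the scatter), so this large change in the group leaves the number in place. The same ring set against hexyl gives a 2.8-fold higher number from compound 1 to compound 3 (0.44 log units; beyond the scatter), which means that at this position the hexyl compound alone stands apart from the other two, and a ring is not needed for a change in the number. No measurement here accounts for these results.

Among these compounds, whether a longer chain such as octyl would carry on the trend from the single chain step remains open. So does the effect of a phenyl ring bearing an amine or a carboxylic acid in place of butyl.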